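The source may hold more compounds than are shown below. What is called first, only, known or untested is meant among the compounds shown, and "the series" means these compounds.

Measured in an ADME assay on Vero cells (Chlorocebus sabaeus) for cytotoxicity, read by resazurin assay, with a stated time of 72 h; a higher number here means a weaker inhibitor, a lower number a stronger inhibitor:

Compound 1, `Cc1ccc(C(=O)CCN2CCN(c3ccc(C(F)(F)F)cc3)CC2)cc1`, gives 140000 nM.
Compound 2, `Cc1ccc(C(=O)CCN2CCN(c3ccc(Cl)cc3)CC2)cc1`, gives 184000 nM.
Compound 3, `O=C(CCN1CCN(c2ccc(C(F)(F)F)cc2)CC1)c1ccc(Br)cc1`, gives 78800 nM.

Compound 4, `O=C(CCN1CCN(c2ccc(Cl)cc2)CC1)c1ccc(Br)cc1`, has not yet been measured in this assay. It differs from compound 3 by chloro in place of trifluoromethyl on an aromatic carbon. The same change, (chloro in place of trifluoromethyl on an aromatic carbon), connects two measured compounds and gave a 1.3-fold higher number from compound 1 to compound 2 (0.12 log units; within the scatter). The two cores differ by bromo in place of methyl on an aromatic carbon, a change that gave a 1.8-fold lower number from compound 1 to compound 3 (0.25 log units; within the scatter). Compound 3 holds the lowest of the three numbers; compound 1 stands nearest to it, within the scatter, while compound 2 stands furthest, beyond the scatter.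

For compound 4 in this assay a step of about a 1.3-fold higher number from compound 3 to compound 4 (0.10 log units; within the scatter) is expected, of the same kind as the earlier one, because a 1.3-fold higher number from compound 1 to compound 2 (0.12 log units; within the scatter) was small and the surroundings of the changed place are the same in both pairs. Compound 4 is therefore estimated at 100000 nM, with a range from 50000 nM to 200000 nM.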

Compound 4, half-maximal inhibitory concentration: 52100 nM
The estimate for compound 4 lay 1.9-fold (0.28 log units) above the measured number; the range from low to high includes it.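

In this assay, chloro in place of trifluoromethyl on the core carrying bromo gave a 1.5-fold lower number from compound 3 to compound 4 (0.18 log units; within the scatter), and this step does not differ from the one seen earlier on the core carrying methyl: the same change on two cores in this assay, a 1.3-fold higher number (0.12 log units; within the scatter) from compound 1 to compound 2 and a 1.5-fold lower number (0.18 log units; within the scatter) from compound 3 to compound 4, 2.0-fold (0.30 log units) apart, within the scatter of two such steps. Bromo in place of methyl, with chloro held fixed, gave a 3.5-fold lower number from compound 2 to compound 4 (0.55 log units; beyond the scatter), the only one of the two new steps beyond the scatter, yet it too cannot be told apart from its earlier counterpart with trifluoromethyl held fixed: the same change on two cores in this assay, a 1.8-fold lower number (0.25 log units; within the scatter) from compound 1 to compound 3 and a 3.5-fold lower number (0.55 log units; beyond the scatter) from compound 2 to compound 4, 2.0-fold (0.30 log units) apart, within the scatter of two such steps. Both changes thus carried from one core to the other with no difference that stands out from the scatter, but two pairs per change do not show that the steps are equal, give the chloro change no settled direction, or say how either change would behave on any other core.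

The compounds shown leave open how a nitrile, a methoxy group or a carboxylic acid would compare at these two places. They also leave open whether the same steps would hold with a longer chain next to the carbonyl.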